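The compounds below may be only part of what the source reports. "The series", "measured", "known", "first", "only" and "open" are said of these compounds alone.

Measured in a functional assay on CHO cells for agonist activity at Free fatty acid receptor 1 (Homo sapiens), read by FLIPR and calcium flux, in the presence of a further agent that is not named here; a higher number here means that more compound is needed for the effect, a lower number that less compound is needed:
Compound 1 `O=C(O)CCc1ccc(OCc2nc(-c3cccc(Br)c3)no2)cc1` gives 1260 nM.
Compound 2 `O=C(O)CCc1ccc(OCc2nc(-c3ccc(C(F)(F)F)cc3)no2)cc1` gives 610 nM.

Compound 2 holds the lowest of the two numbers, and compound 1 sits above it by a step that lies beyond the usual scatter. Both compounds share the same core and differ in the substitution of the six-membered aromatic ring of carbon only, so these two values give a first impression of how that ring matters. Compound 3 `O=C(O)CCc1ccc(OCc2nc(-c3ccc(Cl)cc3)no2)cc1` is the next one to be measured in this assay. The change from compound 2 to compound 3 is modest: chloro in place of trifluoromethyl on an aromatic carbon. Going by the values given here, no measured pair shows this exact exchange, so any expectation rests only on the two numbers seen. A step from compound 2 to compound 3 of about a 1.4-fold higher number from compound 2 to compound 3 (0.14 log units; within the scatter) is expected, towards a somewhat higher number, but not clearly beyond the scatter. For compound 3 the estimate in this assay is 850 nM, with a likely range from 300 nM to 2400 nM.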

Compound 3, half-maximal effective concentration: 540 nM
For compound 3 the middle estimate is 1.6-fold (0.20 log units) above the measured one, and the stated range covers the measured number.
By their numbers in this assay, from the lowest: compounds 3 and 2 (each within the scatter of the next); then compound 1.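

In this assay, the step of a 1.1-fold lower number from compound 2 to compound 3 (0.05 log units; within the scatter) lies within the scatter, so on this aromatic carbon, para to a large group, chloro with its 1 heavy atom cannot be told apart from trifluoromethyl with its 4 heavy atoms. The step of a 2.3-fold lower number from compound 1 to compound 3 (0.37 log units; beyond the scatter) lies beyond the scatter, but the halogen and its place on the ring change together there, so it cannot say which of the two counts. Nothing measured here explains these numbers.

A 4-bromophenyl or a 3-chlorophenyl group would separate the halogen from its place. Going by these compounds, it also remains open whether the same place would tolerate an amine or a carboxylic acid, which differ from all the groups seen so far.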